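The source may report more compounds than this note shows. Statements on the series, on what has been measured and on what is new or still open speak of the compounds shown alone.

Working notes on the macrocyclic series, read out as an ADME assay on liver (Homo sapiens) for metabolic stability, using microsomes; on this read-out lower numbers stand for a shorter-lived compound and higher numbers for a longer-lived compound.

Compound 1 `CN1Cc2cc(ccc2S(=O)(=O)C2CC2)NC(=O)CCc2cccc(c2)[C@@H](Nc2ccc3c(N)ncc(F)c3c2)C1=O` gives 0.217 h in this assay, the highest of the three numbers in hand. Compound 3 `COc1ccc2cc1[C@H](C)CN(C)C(=O)Nc1ccc(S(=O)(=O)C3CC3)c(c1)CN(C)C(=O)C2Nc1ccc2c(N)ncc(F)c2c1` gives 0.1 h, a lower number beyond the scatter relative to compound 1. Compound 2 `CN1CCc2cccc(c2)[C@@H](Nc2ccc3c(N)ncc(F)c3c2)C(=O)N(C)Cc2cc(ccc2S(=O)(=O)C2CC2)NC1=O` gives 0.0833 h, the lowest number, also beyond the scatter from compound 1. Among the measured compounds shown here, no two measured compounds differ in a single place, so no isolated structural step can be read off from these three values.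

Compound 4 `COc1ccc2cc1CCC(=O)Nc1ccc(S(=O)(=O)C3CC3)c(c1)CN(C)C(=O)[C@@H]2Nc1ccc2c(N)ncc(F)c2c1` is the next point. It differs from compound 1 by methoxy in place of hydrogen on an aromatic carbon. Compound 3 carries a methoxy as well, but together with other changes, so its number alone does not pin down that group. The expected step in this assay, a 1.3-fold lower number from compound 1 to compound 4 (0.11 log units; within the scatter), is small, either towards a shorter-lived compound or none beyond the scatter. Compound 4 is estimated at 0.17 h in this assay, within a range of 0.08 h to 0.35 h.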

Compound 4, half-life: 0.233 h
Estimate against measurement, compound 4: 1.4-fold (0.14 log units) below, and the stated range covers the measured number.
By their numbers in this assay, from the lowest: compounds 2 and 3 (each within the scatter of the next); then compounds 1 and 4 (each within the scatter of the next).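

In this assay, methoxy in place of hydrogen on an aromatic carbon gives a 1.1-fold higher number from compound 1 to compound 4 (0.03 log units; within the scatter) and so stays within the scatter. Among the compounds shown here, this is the first comparison that isolates a single change, which compound 3 could not do, as its methoxy comes with other changes. At this place, ortho to a fused ring and para to a fused ring, the read-out does not separate compound 1 from compound 4, and no measurement at hand bears on the reason for this.

Going by these compounds, whether an ethoxy, an amine or a fluorine on the same aromatic carbon would also stay within the scatter remains open. Also open, on these data alone, is whether methoxy at this place would give a similar step on the cores of compound 2 and compound 3.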